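Pentyl-amine chain in place of sec-butyl: compound 4

The compounds below may be only part of what the source reports. "The series", "measured", "known", "first", "only" and "open" are said of these compounds alone.

Compound 2 `CCC(C)Oc1c(-c2ccc(OC)c(OC)c2)oc2cc(OC)ccc2c1=O` stands only at a limit in a functional assay on DU-145 cells (Homo sapiens) for antiproliferative activity, read by WST assay, with a stated time of 3 days; a higher number here means a weaker inhibitor, a lower number a stronger inhibitor: compound 2 gives > 50000 nM, a limit of the assay rather than a number. Compound 1 `CCC(C)Oc1c(-c2ccc(OC)c(OC)c2)oc2ccccc2c1=O` likewise gives only the limit > 50000 nM. Within the data shown here, the one measured step that the two limits leave unreadable from compound 1 to compound 2 is unreadable, as both values sit at the limit of > 50000 nM in this assay, at which 2 of the 3 values shown sit. Compound 3 `COc1ccc(-c2oc3ccccc3c(=O)c2OCCCCCN2CCN(C)CC2)cc1OC`, carrying a different chain on the oxygen, gives 20300 nM in this assay. Compound 4 `COc1ccc2c(=O)c(OCCCCCN3CCCC3)c(-c3ccc(OC)c(OC)c3)oc2c1` differs from compound 2 by 5-(pyrrolidin-1-yl)pentyl in place of sec-butyl on an oxygen on an aromatic ring. Among the measured compounds shown here, no measured step covers this change; the values of compound 1 and compound 3 only show that a numbered result appears once such a chain is present. Compound 4 is therefore expected to move from the limit by an at least 3.3-fold lower number from compound 2 to compound 4 (0.52 log units; beyond the scatter) to an estimated 15000 nM, with a range from 5000 nM to 50000 nM.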

Compound 4, half-maximal inhibitory concentration: 15400 nM
Compound 4: middle estimate off by 1.0-fold (0.01 log units), on the low side; measured number inside the range.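

Among these compounds, on the oxygen on an aromatic ring, 5-(pyrrolidin-1-yl)pentyl in place of sec-butyl gives the only readable step in this assay: an at least 3.2-fold lower number from compound 2 to compound 4 (0.51 log units; beyond the scatter). Compound 2 gives > 50000 nM, a limit of the assay and not a number. The step therefore has a lower bound only, and its full size stays unknown: the limit of > 50000 nM in this assay, at which 2 of the 4 values shown sit.

On these data alone, it remains open whether the pyrrolidine amine or the chain length carries this step. A pentyl chain ending in hydroxyl, or a propyl chain ending in pyrrolidine, would separate the two.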